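A few compounds are considered here, and "the series" means these few. Any claim that something is new, unique, unknown or untested is made for them only; others in the source may bear on it.

Compound 1, `COc1ccccc1C(=O)Nc1cccc(NC(=O)c2cccc(F)c2)c1`, in an in vitro functional assay on HEK293-A cells for antagonist activity at metabotropic glutamate receptor 5 (Rattus norvegicus), read by calcium flux (a higher number here means a weaker inhibitor, a lower number a stronger inhibitor), gives 6480 nM.
Compound 2, `COc1ccccc1C(=O)Nc1cccc(NC(=O)c2ccco2)c1`, gives in this assay the value > 30000 nM, which is a limit of the assay and not a number.
Compound 3, `COc1cc(NC(=O)c2cccc(N3C(=O)c4ccccc4C3=O)c2)cc(OC)c1`, gives in this assay the value 3580 nM.

Compound 3 has the lowest of the two numbers in this assay; its nearest neighbour is compound 1, and the gap between the two lies within the scatter, so no order between them is claimed. Within the data shown here, the one measured step in this assay is an at least 4.6-fold higher number from compound 1 to compound 2 (0.66 log units; beyond the scatter); it concerns the group on a carbonyl carbon, with the limit of > 30000 nM in this assay, at which 1 of the 3 values shown sits, as the only evidence on it.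

Compound 4, `O=C(NC1CC2CCC1C2)c1cccc(N2C(=O)c3ccccc3C2=O)c1`, is not yet measured. It differs from compound 3 by a group of 7 heavy atoms (7 carbon; 2 five-membered non-aromatic rings of carbon only) in place of a group of 10 heavy atoms (8 carbon, 2 oxygen; one six-membered aromatic ring of carbon only), on an amide-type nitrogen. Among the measured compounds shown here, none of the measured steps touches the group on the amide-type nitrogen; the step from compound 1 to compound 2 changes the carbonyl side and gives no direct guidance here. The change removes the only aromatic ring on that side of the shared core, so a modest weakening is expected rather than none, while a stronger result cannot be excluded. For compound 4 the expected step is a 2.2-fold higher number from compound 3 to compound 4 (0.35 log units; beyond the scatter). Compound 4 is therefore estimated at 8000 nM in this assay, within a range from 1500 nM to 30000 nM.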

Compound 4, half-maximal inhibitory concentration: > 30000 nM
Compound 4 gave a limit, no number; the forecaster's own chance of this, stated with the estimate: 30%; middle value at least 3.7-fold (0.57 log units) from the limit.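

In this assay, among these compounds, the replacement of 3,5-dimethoxyphenyl on the amide-type nitrogen gives an at least 8.3-fold higher number from compound 3 to compound 4 (0.92 log units; beyond the scatter), the first measured step at this position, and it shows that the position does not tolerate every group. For compound 4, the value > 30000 nM is a limit of the assay and not a number. Both measured steps in the series now end at the same limit, leaving the full size of each unknown: the limit of > 30000 nM in this assay, at which 2 of the 4 values shown sit.

The step from 3,5-dimethoxyphenyl to the group with two five-membered non-aromatic rings of carbon only changes the ring type and removes both methoxy groups at once, so it cannot say which of these changes matters; an unsubstituted phenyl or a cyclohexyl on the same nitrogen would separate them. From the compounds shown here alone, it also remains open whether the amide-type nitrogen accepts any group with a nitrogen atom, such as a pyridine ring or a morpholine, and whether the carbonyl side and the amide-type nitrogen contribute independently, since compound 1 and compound 3 differ in more than one place.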